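The source may report more compounds than this note shows. Statements on the series, on what has been measured and on what is new or still open speak of the compounds shown alone.

Compound 1 `CC1CCN(C2CCN(S(=O)(=O)c3ccc(C(C)(C)C)cc3)CC2)CC1`: in a functional assay on DLD-1 cells (Homo sapiens) for antiproliferative activity, read by CellTiter-Glo, with a stated time of 72 h (a lower number here means a stronger inhibitor, a higher number a weaker inhibitor), compound 1 gives > 5000 nM, which is a limit of the assay and not a number.
Compound 2 `CCCC(=O)N(Cc1ccccc1)C1CCN(S(=O)(=O)c2c(C)cc(C)cc2C)CC1`: compound 2 gives > 5000 nM, again a limit.
Compound 3 `Cc1cccc(S(=O)(=O)N2CCC(N3CCC(C)CC3)CC2)c1`: compound 3 gives 25 nM.

Compound 1 therefore stands at the upper edge of what this assay reports, as does compound 2 (the limit of > 5000 nM in this assay, at which 2 of the 3 values shown sit). Only compound 3, which shares the same core of compound 1 but carries a different group on the aromatic ring, gives a number, and that number is small. Within the data shown here, no measured pair differs in a single place, so no step between measured compounds is available.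

Compound 4 `COc1ccc(-c2ccc(S(=O)(=O)N3CCC(N4CCC(C)CC4)CC3)cc2)cc1` is not yet measured. It differs from compound 1 in one place (4-methoxyphenyl in place of tert-butyl on an aromatic carbon). Because compound 1 sits at a limit, any number for compound 4 would be a step downward, and the expectation is that the step from compound 1 to compound 4 is an at least 6.2-fold lower number from compound 1 to compound 4 (0.79 log units; beyond the scatter), toward a stronger inhibitor. The supporting point is that compound 3 gives 25 nM with a smaller group on the same ring, showing the core can be active. Compound 4 is estimated at 800 nM, within 100 nM to 5000 nM.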

Compound 4, half-maximal inhibitory concentration: 263 nM
Compound 4: the middle estimate sits 3.0-fold (0.48 log units) above what was measured, within the range that was stated.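

At this aromatic carbon the group decides whether this assay returns a number at all: putting 4-methoxyphenyl in place of tert-butyl gives an at least 19-fold lower number from compound 1 to compound 4 (1.27 log units; beyond the scatter). The entering group has more heavy atoms than the one that leaves, so a larger group at this place does not by itself leave a compound at the limit. Compound 1 gives > 5000 nM, which is a limit, so the size of this step has only a lower bound: the limit of > 5000 nM in this assay, at which 2 of the 4 values shown sit.

The compounds shown do not separate the effect of the added aromatic ring from that of its methoxy group, which a plain phenyl at this carbon would help to do. They also leave open how an amine or a carboxylic acid in place of that methoxy group would read in this assay.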